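The source may hold more compounds than are shown below. What is called first, only, known or untested is meant among the compounds shown, and "the series" means these compounds.

Measured compounds:
compound 1 `CCCCCCCCCCCC[C@@H](O)[C@H]1CC[C@H]([C@H](O)CCCCCCCCCCNC(=O)c2cncs2)O1` gives 100000 nM in a functional assay on ACHN cells (Homo sapiens) for inhibition, read by colorimetric assay and sulforhodamine B assay, with a stated time of 48 h; a lower number here means a stronger inhibitor of growth, a higher number a weaker inhibitor of growth
compound 2 `CCCCCCCCCCCC[C@@H](O)[C@H]1CC[C@H]([C@H](O)CCCCCCCCCCNC(=O)c2ccsc2)O1` gives 3890 nM in this assay

Compound 1 stands highest of the two numbers in this assay; its nearest neighbour is compound 2, reached by a 26-fold lower number from compound 1 to compound 2 (1.41 log units; beyond the scatter). Compound 3 `CCCCCCCCCCCC[C@@H](O)[C@H]1CC[C@H]([C@H](O)CCCCCCCCCCNC(=O)c2cccs2)O1` differs from compound 1 by thiophen-2-yl in place of 1,3-thiazol-5-yl on a carbonyl carbon. Among the measured compounds shown here, the one step that bears on this change is the swap from compound 1 to compound 2, which was large and downward. A step of comparable size and direction is therefore expected here, a 22-fold lower number from compound 1 to compound 3 (1.35 log units; beyond the scatter). Compound 3 is expected to give about 4500 nM in this assay, with a range from 1000 nM to 25000 nM.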

Compound 3, concentration for 50% growth inhibition: 2570 nM
The estimate for compound 3 lay 1.8-fold (0.24 log units) above the measured number; the range from low to high includes it.
By their numbers in this assay, from the lowest: compounds 3 and 2 (each within the scatter of the next); then compound 1.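

Thiophen-2-yl on the carbonyl carbon also gives a large change in this assay (a 39-fold lower number from compound 1 to compound 3 (1.59 log units; beyond the scatter)), so the lower number seen with thiophen-3-yl is not tied to that one attachment. The two thiophene attachments cannot be separated here (a 1.5-fold lower number from compound 2 to compound 3 (0.18 log units; within the scatter)), which leaves compound 1, with its 1,3-thiazol-5-yl, alone at the high end of the three. Nothing available accounts for this difference.

Still open, from the compounds shown here alone, is whether phenyl or pyridin-3-yl on the carbonyl carbon gives numbers like those of compound 2 and compound 3. Also open, going by these compounds, is how a methyl or chlorine on the thiophen-2-yl ring would shift the number.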